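The source may hold more compounds than are shown below. What is called first, only, known or untested is meant among the compounds shown, and "the series" means these compounds.

Measured compounds:
- compound 1 `O=C(/C=C/c1cccc(OCc2ccccc2)c1)c1ccc([N+](=O)[O-])cc1` — 17500 nM in a functional assay on MCF7 cells (Homo sapiens) for cytotoxicity, read by MTT assay, with a stated time of 68 h; on this read-out lower numbers stand for stronger inhibition and higher numbers for weaker inhibition
- compound 2 `O=C(/C=C/c1cccc(OCc2ccccc2)c1)c1ccccc1` — compound 2 gives 9800 nM
- compound 3 `O=C(/C=C/c1cccc(OCc2ccccc2)c1)c1cccc(Br)c1` — compound 3 gives 7900 nM

Compound 1 stands at the highest of the three numbers in this assay. Its nearest neighbour is compound 2, and the step of a 1.8-fold lower number from compound 1 to compound 2 (0.25 log units; within the scatter) is within the scatter; the step of a 2.2-fold lower number from compound 1 to compound 3 (0.35 log units; beyond the scatter) is a modest one beyond it. Between the other two, the step of a 1.2-fold lower number from compound 2 to compound 3 (0.09 log units; within the scatter) is within the scatter, so the three compounds are close together and only compound 3 separates itself from compound 1, and only modestly.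

Compound 4 `COc1ccc(C(=O)/C=C/c2cccc(OCc3ccccc3)c2)cc1` is not yet measured. Its difference from compound 1 is this: methoxy in place of nitro on an aromatic carbon. It sits on an aromatic carbon of a six-membered aromatic ring of carbon only, the same ring where the change from compound 1 to compound 2 removed the nitro. That step, a 1.8-fold lower number from compound 1 to compound 2 (0.25 log units; within the scatter), bears most directly on the present one, since both take the nitro away; the step of a 2.2-fold lower number from compound 1 to compound 3 (0.35 log units; beyond the scatter) also replaces the nitro, with a modest drop. Nothing measured shows what a methoxy itself does. A small drop, not clearly beyond the scatter, is therefore expected for compound 4, about a 1.8-fold lower number from compound 1 to compound 4 (0.24 log units; within the scatter). Compound 4 is estimated at 10000 nM, within a range from 4500 nM to 22000 nM.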

Compound 4, half-maximal inhibitory concentration: 6000 nM
Beside the measured number, compound 4's estimate is 1.7-fold (0.22 log units) above it; the measured number falls inside the stated range.
By their numbers in this assay, from the lowest: compounds 4, 3, 2 and 1 (each within the scatter of the next, the first and the last beyond it).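

In this assay, within the data shown here, the step of a 2.9-fold lower number from compound 1 to compound 4 (0.46 log units; beyond the scatter) is the first change confined to this carbon, para to a large group, that lies beyond the scatter, whereas taking the nitro away without a replacement did not go beyond it. The gain over compound 1 is nevertheless modest, and the methoxy is not separated from a bare ring, since the step of a 1.6-fold lower number from compound 2 to compound 4 (0.21 log units; within the scatter) stays within the scatter. The 4-methoxyphenyl likewise cannot be told apart from the 3-bromophenyl, with the step of a 1.3-fold lower number from compound 3 to compound 4 (0.12 log units; within the scatter) also within the scatter, so the result marks out compound 1 from compound 4 but gives no clear order among compounds 2, 3 and 4.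

As far as these compounds go, whether an amine, a hydroxyl or a longer chain such as ethoxy at this carbon would carry the number beyond the scatter of compound 2 remains open, as does whether a methoxy elsewhere on the ring would match the one here. The compounds shown come with no evidence on what lies behind these steps.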